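This account rests on a few compounds, and the source may have more. Where it says the series, first, only, none or still open, it means among the compounds named here.

Measured so far in an assay on isolated protein (Sus scrofa) for inhibition of glycogen phosphorylase, brain form (Homo sapiens); a higher number here means a weaker inhibitor, a lower number a stronger inhibitor:
compound 1 `O=C(Nc1ccccc1)[C@H]1O[C@H](CO)[C@@H](O)[C@H](O)[C@H]1O` gives 12600000 nM;
compound 2 `O=C(Nc1ccccc1)[C@@H]1O[C@H](CO)[C@@H](O)[C@H](O)[C@H]1O` gives 5010000 nM.

Compound 2 stands at the lowest of the two numbers, the step being a 2.5-fold lower number from compound 1 to compound 2 (0.40 log units; beyond the scatter), which rests on (the fact that compounds 1 and 2 differ only in the configuration as drawn).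

Compound 3 `O=C(NC1CC1)[C@@H]1O[C@H](CO)[C@@H](O)[C@H](O)[C@H]1O` differs from compound 2 by cyclopropyl in place of phenyl on an amide-type nitrogen. Going by the values given here, no measured step changes the group on the amide nitrogen; the only step, from compound 1 to compound 2, concerns configuration alone, so it gives no guide to this change. The expectation for compound 3 in this assay is therefore wide, with a step of a 2.0-fold higher number from compound 2 to compound 3 (0.30 log units; within the scatter) and an estimate of 10000000 nM, between 3000000 nM and 40000000 nM.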

Compound 3, inhibition constant: 1260000 nM
Estimate against measurement, compound 3: 7.9-fold (0.90 log units) above; measured number below the stated range.
By their numbers in this assay, from the lowest: compound 3; then compound 2; then compound 1.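

Cyclopropyl in place of phenyl on the amide-type nitrogen gives a 4.0-fold lower number from compound 2 to compound 3 (0.60 log units; beyond the scatter), so in this assay the number responds to the group at this position, and the aromatic ring of phenyl is not required there. Nothing measured here gives a reason for this step.

Still open, from the compounds shown here alone, is how this position responds to other groups, such as a longer carbon chain, an amine or a carboxylic acid. Also open, going by these compounds, is whether cyclopropyl gives a similar step on the configuration drawn in compound 1.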